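The compounds below may be only part of what the source reports. "The series", "measured", "known", "first", "only" and "open" are said of these compounds alone.

Of the compounds shown here, three sharing a fluorinated bicyclic benzylamine side chain have been tested in an ADME assay on microsomes from liver (Homo sapiens) for metabolic stability, read by LC-MS, using NADPH, with stated times of 5 min and 30 min, tested at 1 uM; a lower number here means slower removal, a higher number faster removal of the compound. Compound 1 `Cc1ncccc1-c1cnc(NCc2c(F)ccc3c2CCO3)c2nn(CC#N)c(=O)n12` gives 151 mL.min-1.g-1. Compound 3 `Cc1ncccc1-c1cnc(NCc2c(F)ccc3c2CCO3)c2cn[nH]c(=O)c12` gives 41 mL.min-1.g-1. Compound 2 `COCCC(=O)Nc1cnc(NCc2c(F)ccc3c2CCO3)n2cnnc12` reads < 3 mL.min-1.g-1, which is a limit of the assay and not a number. Compound 2 therefore stands at the limit of < 3 mL.min-1.g-1 in this assay, at which 1 of the 3 values shown sits, and its true clearance is not known.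

Compound 4 `O=C(Nc1cnc(NCc2c(F)ccc3c2CCO3)n2cnnc12)c1cccnc1` departs from compound 2 in one place, with pyridin-3-yl in place of 2-methoxyethyl on a carbonyl carbon. Among the measured compounds shown here, no measured pair of compounds isolates this kind of change, so its size in this assay can only be judged loosely. Any change that can be seen from the limit of compound 2 would be upward, and a modest rise is expected rather than a jump to the numbers of the other two compounds. The expected move is an at least 2.6-fold higher number from compound 2 to compound 4 (0.42 log units; beyond the scatter). For compound 4 the intrinsic clearance in microsomes is estimated at 8 mL.min-1.g-1, within an expected range of 3 mL.min-1.g-1 to 30 mL.min-1.g-1.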

Compound 4, intrinsic clearance in microsomes: < 3 mL.min-1.g-1
Compound 4: a limit, no number; the forecaster's own chance of this, stated with the estimate: 25%; at least 2.6-fold (0.42 log units) between middle value and limit.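

Compound 2 and compound 4 both read as limits in this assay and not as numbers, so no step can be read between them. The compounds shown leave open whether pyridin-3-yl in place of 2-methoxyethyl on a carbonyl carbon changes clearance at all.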